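The source may hold more compounds than are shown below. What is called first, only, known or untested is meant among the compounds shown, and "the series" means these compounds.

The series is read in a functional assay on DU-145 cells (Homo sapiens) for cytotoxicity, read by MTT assay, with a stated time of 72 h; a lower number here means that less compound is needed, a higher number that more compound is needed for the effect. Compound 1 `CCc1cccc2c(OC(C)=O)c(-c3occ(C)c3COC(C)=O)ccc12` gives > 10 ug/mL in this assay, which is a limit rather than a number. Compound 2 `CCc1cccc2c(OC)c(-c3occ(C)c3COC)ccc12` gives > 10 ug/mL in this assay, again a limit and not a measured value. On the numbers shown, compound 2 stands at the limit of > 10 ug/mL in this assay, at which 2 of the 2 values shown sit, with no numerical value of its own. Among the measured compounds shown here, no two measured compounds differ in one place, so no measured step is available. Compound 3 `CCc1cccc2c(OC)c(-c3occ(C)c3COC(C)=O)ccc12` is not yet measured and differs from compound 2 by acetyl in place of methyl on an oxygen on a saturated carbon. Compound 1 with acetoxy and acetoxymethyl and compound 2 with methoxy and methoxymethyl both stop at the same limit, so in this assay no step beyond the scatter is expected in either direction. Compound 3 is expected to stay at the limit too, estimated at 15 ug/mL with a range of 5 ug/mL to 50 ug/mL. The expected step that the limit leaves unreadable from compound 2 to compound 3 is none beyond the scatter.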

Compound 3, concentration for half-maximal effect: > 10 ug/mL
Compound 3: a limit, no number (the forecaster's own chance of this, stated with the estimate: 80%); the middle value does not contradict the limit.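

Compound 1, compound 2 and compound 3 are all limits in this assay, and no step to compound 3 can be read: the limit of > 10 ug/mL in this assay, at which 3 of the 3 values shown sit.

The compounds shown leave open at what concentration any of them reaches half-maximal effect, and whether methoxy or acetoxy makes a difference there.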